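This account rests on a few compounds, and the source may have more. Where it says the series, first, only, none or still open, it means among the compounds named here.

Three imines built on a shared core have been measured in an assay on isolated protein for inhibition of Amine oxidase [flavin-containing] B (Homo sapiens), read by fluorescence and Amplex Red, with stated times of 15 min and 20 min; a lower number here means a stronger inhibitor, a higher number a weaker inhibitor. Compound 1 `COc1cccc(/C=N/c2ccc(OCc3ccccc3)cc2)c1O` gives 6500 nM. Compound 2 `Oc1cccc(/C=N/c2ccc(OCc3ccccc3)cc2)c1O` gives 6870 nM. Compound 3 `Oc1ccc(/C=N/c2ccc(OCc3ccccc3)cc2)c(O)c1O` gives 1730 nM. Compound 2 therefore holds the highest of the three numbers; its nearest neighbour is compound 1, and the step of a 1.1-fold higher number from compound 1 to compound 2 (0.02 log units; within the scatter) lies within the scatter, while its furthest is compound 3, reached by the step of a 4.0-fold lower number from compound 2 to compound 3 (0.60 log units; beyond the scatter), which is beyond the scatter.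

Compound 4 `Cc1ccc(O)c(/C=N/c2ccc(OCc3ccccc3)cc2)c1` has not yet been measured in this assay. It differs from compound 2 by 2-hydroxy-5-methylphenyl in place of 2,3-dihydroxyphenyl on a carbon with a double bond to nitrogen. Among the compounds with values here, two measured steps bear on this change. The step of a 1.1-fold higher number from compound 1 to compound 2 (0.02 log units; within the scatter) shows that exchanging methyl for hydrogen on an oxygen of this ring leaves the number where it was. The step of a 4.0-fold lower number from compound 2 to compound 3 (0.60 log units; beyond the scatter) shows that adding a hydroxy lowers the number modestly; compound 4 instead carries one hydroxy fewer than compound 2, together with a methyl, so a small rise in the number, or none beyond the scatter, is the expectation. Compound 4 is accordingly estimated at 9500 nM, within a range from 4000 nM to 22000 nM, an expected step of a 1.4-fold higher number from compound 2 to compound 4 (0.14 log units; within the scatter).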

Compound 4, half-maximal inhibitory concentration: 24600 nM
Beside the measured number, compound 4's estimate is 2.6-fold (0.41 log units) below it; measured number above the stated range.
By their numbers in this assay, from the lowest: compound 3; then compounds 1 and 2 (each within the scatter of the next); then compound 4.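

The a 3.6-fold higher number from compound 2 to compound 4 (0.55 log units; beyond the scatter) in this assay shows that the aryl group on the carbon with a double bond to nitrogen is not indifferent to change, even though the exchange of methyl for hydrogen on an oxygen of this ring had left the number where it was. Read with the step from compound 2 to compound 3, it gives a series in which compound 3, compound 2 and compound 4 climb in number as hydroxy groups on this ring fall away, and compound 1 stands outside that simple reading, as it holds a methoxy in place of one hydroxy yet lies within the scatter of compound 2. Nothing available accounts for the size of this rise.

Because the change from compound 2 to compound 4 removes a hydroxy and adds a methyl in one step, the compounds shown leave open how much of the rise belongs to each of the two. They also leave open whether a plain 2-hydroxyphenyl group, or an amine or a carboxylic acid on this ring, would bring the number down or send it higher.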